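The source may report more compounds than this note shows. Statements on the series, on what has been measured and on what is new or still open speak of the compounds shown alone.

Compound 1, `Cc1ccc(Nc2nc(C(F)(F)F)ccc2CNC(=O)C(C)c2ccc(NS(C)(=O)=O)c(F)c2)cc1C`, gives 1160 nM in a functional assay on CHO-K1 cells for antagonist activity at transient receptor potential cation channel subfamily V member 1 (Homo sapiens), read by FLIPR; on this read-out lower numbers stand for stronger inhibition and higher numbers for weaker inhibition. Among the two compounds with a number, compound 1 stands highest; compound 2, `CC(C(=O)NCc1ccc(C(F)(F)F)nc1NCc1ccccc1)c1ccc(NS(C)(=O)=O)c(F)c1`, gives 203 nM, and the step of a 5.7-fold lower number from compound 1 to compound 2 (0.76 log units; beyond the scatter) is a modest one. Compound 3, `CC(C(=O)NCc1ccc(C(F)(F)F)nc1N1CCC(O)CC1)c1ccc(NS(C)(=O)=O)c(F)c1`, is reported as "not active" (no number reported), so no number is available for it. The new compound, compound 4, `CC(C(=O)NCc1ccc(C(F)(F)F)nc1N1CCC(CN(C)C)CC1)c1ccc(NS(C)(=O)=O)c(F)c1`, differs from compound 1 in one place: 4-((dimethylamino)methyl)piperidin-1-yl in place of (3,4-dimethylphenyl)amino on an aromatic carbon.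

For the measured compounds named here, no measured step covers this change directly. Going by the values given here, the only step with a number, from compound 1 to compound 2, swaps one group on the nitrogen for another while keeping that nitrogen; the change to compound 4 removes the amino link entirely and puts a piperidine ring straight onto the aromatic carbon, as in compound 3. Among the compounds with values here, compound 3 is the closest precedent, and it gave "not active" (no number reported). She therefore expects compound 4 to lose activity relative to compound 1, with a 6.9-fold higher number from compound 1 to compound 4 (0.84 log units; beyond the scatter) as her estimate, and a real chance that no number is obtained at all. For compound 4 she estimates 8000 nM, within 2500 nM to 30000 nM.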

Compound 4, half-maximal inhibitory concentration: 426 nM
Beside the measured number, compound 4's estimate is 19-fold (1.27 log units) above it, and the stated range ends above it.
By their numbers in this assay, from the lowest: compound 2; then compound 4; then compound 1.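

In this assay, the aromatic carbon next to the ring nitrogen does not need the amino link to give a measurable number: 4-((dimethylamino)methyl)piperidin-1-yl in place of (3,4-dimethylphenyl)amino gives (a 2.7-fold lower number from compound 1 to compound 4 (0.44 log units; beyond the scatter)), while in place of benzylamino it gives (a 2.1-fold higher number from compound 2 to compound 4 (0.32 log units; beyond the scatter)). A piperidine ring set directly on this carbon therefore does not by itself go with a lack of activity, since compound 3, with its hydroxy-bearing ring, is reported as ("not active" (no number reported)) whereas compound 4 gives (426 nM). Nothing measured here accounts for these differences.

The compounds shown leave open how much of this result rests on the dimethylamino group itself. A piperidine ring carrying a plain methyl group or a primary aminomethyl group at that place would separate the amine from the ring and its chain.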